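The source may hold more compounds than are shown below. What is called first, only, known or untested is meant among the compounds shown, and "the series" means these compounds.

Measured compounds in a functional assay on HepG2 cells (Homo sapiens) for inhibition, read by MTT assay, with a stated time of 72 h; on this read-out lower numbers stand for stronger inhibition and higher numbers for weaker inhibition:
compound 1 `CN(C(=O)NC(=O)c1ccc(F)c(F)c1)c1nc(C(F)(F)F)c(C(=O)N/N=C/c2ccc(C(F)(F)F)cc2)s1` gives 6.26 ug/mL
compound 2 `CN(C(=O)NC(=O)c1ccccc1F)c1nc(C(F)(F)F)c(C(=O)N/N=C/c2ccccc2C(F)(F)F)s1` gives 5.39 ug/mL
compound 3 `CN(C(=O)NC(=O)c1ccccc1F)c1nc(C(F)(F)F)c(C(=O)N/N=C/c2cccc(C(F)(F)F)c2)s1` gives 20.3 ug/mL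

Compound 3 stands highest of the three numbers; compound 1 sits nearest to it and compound 2 furthest, both with lower numbers, and both gaps are beyond the scatter.

Compound 4 `CN(C(=O)NC(=O)c1ccccc1F)c1nc(C(F)(F)F)c(C(=O)N/N=C/c2ccc(C(F)(F)F)cc2)s1` is not yet measured. It differs from compound 3 in one place: 4-(trifluoromethyl)phenyl in place of 3-(trifluoromethyl)phenyl on a carbon with a double bond to nitrogen.

Among the measured compounds shown here, one measured step bears on this change. The step of a 3.8-fold higher number from compound 2 to compound 3 (0.58 log units; beyond the scatter) moved the trifluoromethyl around the same phenyl ring and produced a modest rise in the number. Compound 1 carries the same 4-(trifluoromethyl)phenyl that enters in compound 4, though with a different acyl group elsewhere, and its number in this assay sits well below that of compound 3. Taken together, moving the trifluoromethyl away from the position held in compound 3 is expected to bring the number down again, by a modest step, a 2.7-fold lower number from compound 3 to compound 4 (0.43 log units; beyond the scatter).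

Compound 4 is therefore estimated at 7.5 ug/mL in this assay, with a range from 3.5 ug/mL to 17 ug/mL.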

Compound 4, half-maximal inhibitory concentration: 4.56 ug/mL
Compound 4: middle estimate off by 1.6-fold (0.22 log units), on the high side, within the range that was stated.
By their numbers in this assay, from the lowest: compounds 4, 2 and 1 (each within the scatter of the next); then compound 3.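

In this assay the change to 4-(trifluoromethyl)phenyl on the carbon with a double bond to nitrogen brings a 4.5-fold lower number from compound 3 to compound 4 (0.65 log units; beyond the scatter) and shows that the number does not keep rising as the trifluoromethyl moves around the ring. The step with 2-(trifluoromethyl)phenyl as the starting group gives a 1.2-fold lower number from compound 2 to compound 4 (0.07 log units; within the scatter) so these two groups cannot be told apart, and among compound 2, compound 3 and compound 4 only the 3-(trifluoromethyl)phenyl stands apart. With 4-(trifluoromethyl)phenyl held fixed, 2-fluorophenyl in place of 3,4-difluorophenyl on a carbonyl carbon gives a 1.4-fold lower number from compound 1 to compound 4 (0.14 log units; within the scatter) and so this change does not separate the pair.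

On these data alone, whether a methoxy group or a nitrile in place of the trifluoromethyl would keep the number as low remains open. Nothing measured here explains why the 3-(trifluoromethyl)phenyl stands apart.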